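A few compounds are considered here, and "the series" means these few. Any claim that something is new, unique, unknown or untested is made for them only; others in the source may bear on it.

Compound 1 `COC(=O)c1ccc(NC(=O)[C@H]2CC=C(CCC=C(C)C)C[C@@H]2c2ccccc2)cc1` was tested in an assay on isolated protein for inhibition of Apoptosis regulator Bcl-2 (Homo sapiens), read by fluorescence polarization, with stated times of 5 min and 10 min; a lower number here means a stronger inhibitor, a higher number a weaker inhibitor. In this assay compound 1 gives > 23000 nM, which is a limit of the assay rather than a number. Compound 2 `CC(C)=CCCC1=CC[C@H](C(=O)Nc2ccc(O)cc2)[C@@H](c2ccccc2)C1` carries a hydroxy in place of the methoxycarbonyl on an aromatic carbon. In this assay compound 2 gives > 23000 nM, also a limit. The step that the two limits leave unreadable from compound 1 to compound 2 therefore cannot be read, because both values sit at the limit of > 23000 nM in this assay, at which 2 of the 2 values shown sit. Compound 3 `COC(=O)c1ccc(NC(=O)[C@@H]2CC=C(CCC=C(C)C)C[C@H]2c2ccccc2)cc1` is the compound still to be measured: the two compounds have the same atoms and bonds and differ only in configuration as drawn: 2 of 2 stereo elements differ (all stereocentres are inverted: mirror images); a stereocentre at a saturated ring carbon is drawn S in compound 1 and R in compound 3; a stereocentre at a saturated ring carbon is drawn S in compound 1 and R in compound 3. Among the measured compounds shown here, no measured step touches a change in configuration, and the one measured step gives no size at all, so compound 1 offers only a limit as a starting point. The step that the limit leaves unreadable from compound 1 to compound 3 is expected to stay within the usual scatter or to remain unreadable. Compound 3 is therefore estimated at 30000 nM, with a range from 8000 nM to 100000 nM.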

Compound 3, inhibition constant: > 23000 nM
Compound 3: no number, only a limit; the forecaster's own chance of this, stated with the estimate: 75%; the middle value lies beyond the limit too.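

In this assay compound 3 gives > 23000 nM, which is a limit and not a number. Among the compounds shown here, no step from compound 1 to compound 3 can therefore be read: the limit of > 23000 nM in this assay, at which 3 of the 3 values shown sit. The compounds shown leave open whether mirror-image configuration changes binding at all, since none of them has an actual number.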